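The compounds below may be only part of what the source reports. "The series", "measured", "known", "first", "only" and "open" are said of these compounds alone.

In a functional assay on L1210 cells (Mus musculus) for cytotoxicity (on this read-out higher numbers stand for weaker inhibition and lower numbers for stronger inhibition), two compounds of the series have numbers. Compound 1 `COc1ccc(NC(=O)/C=C/C(=O)N2C/C(=C\c3ccc([N+](=O)[O-])cc3)C(=O)/C(=C/c3ccc([N+](=O)[O-])cc3)C2)cc1` gives 2900 nM, and compound 2 `O=C(/C=C/C(=O)N1C/C(=C\c2ccc([N+](=O)[O-])cc2)C(=O)/C(=C/c2ccc([N+](=O)[O-])cc2)C1)Nc1ccc(Cl)c(Cl)c1` gives 1700 nM; the step of a 1.7-fold lower number from compound 1 to compound 2 (0.23 log units; within the scatter) lies within the scatter, so compound 2 holds the lower of the two numbers without standing apart from compound 1. Compound 3 `CC(=O)c1ccc(NC(=O)/C=C/C(=O)N2C/C(=C\c3ccc([N+](=O)[O-])cc3)C(=O)/C(=C/c3ccc([N+](=O)[O-])cc3)C2)cc1` is not yet measured; it differs from compound 2 by 4-acetylphenyl in place of 3,4-dichlorophenyl on an amide-type nitrogen. Within the data shown here, only one measured step touches the same position, and that step, a 1.7-fold lower number from compound 1 to compound 2 (0.23 log units; within the scatter), did not move the number beyond the scatter, so no exchange at the amide-type nitrogen has yet shifted this assay . The expectation for compound 3 is therefore a step of a 1.3-fold higher number from compound 2 to compound 3 (0.11 log units; within the scatter), no clear direction and no change beyond the scatter. Compound 3 is estimated at 2200 nM in this assay , with a range from 900 nM to 5500 nM.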

Compound 3, half-maximal inhibitory concentration: 1400 nM
Estimate against measurement, compound 3: 1.6-fold (0.20 log units) above; measured number inside the range.
By their numbers in this assay, from the lowest: compounds 3, 2 and 1 (each within the scatter of the next, the first and the last beyond it).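

In this assay, the exchange of 3,4-dichlorophenyl for 4-acetylphenyl on the amide-type nitrogen gives a 1.2-fold lower number from compound 2 to compound 3 (0.08 log units; within the scatter), so a second exchange at this position leaves the number within the scatter. Among these compounds, the exchange of methoxy for acetyl on an aromatic carbon gives a 2.1-fold lower number from compound 1 to compound 3 (0.32 log units; beyond the scatter), the first step at this position to pass the scatter, though only modestly, and compound 2 stays within the scatter of both other compounds. No supporting data are available to explain this small separation.

From the compounds shown here alone, all three groups on the amide-type nitrogen are substituted phenyl rings, so it remains open whether a dimethylamino group or a carboxylic acid in place of the acetyl would widen the separation. Also open, going by these compounds, is how a simple butyl chain in place of the phenyl ring would read out.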